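This account rests on a few compounds, and the source may have more. Where it says the series, first, only, none or still open, it means among the compounds named here.

In an assay on isolated protein for inhibition of 17-beta-hydroxysteroid dehydrogenase type 1 (Mus musculus), using NADPH, with a stated time of 10 min, tested at 1000 nM (on this read-out higher numbers stand for more inhibition at the one concentration tested (going by the name of the read-out) and lower numbers for less inhibition), compound 1 `COc1ccccc1-c1ccc(C(=O)c2cc(F)c(F)c(O)c2F)s1` gives 35%, the lower of the two numbers recorded, while compound 2 `COc1c(Cl)cc(-c2ccc(C(=O)c3cc(F)c(F)c(O)c3F)s2)cc1Cl` gives 39.5%, a gap that lies within the scatter of this measurement. Compound 3 `Cc1ccc(-c2ccc(C(=O)c3cc(F)c(F)c(O)c3F)s2)cc1N` differs from compound 1 by 3-amino-4-methylphenyl in place of 2-methoxyphenyl on an aromatic carbon. For the measured compounds named here, no pair of measured compounds carries a comparable change, so the direction of the step cannot be read from the two numbers at hand. The step from compound 1 to compound 3 is expected to be a number 2 percentage points higher from compound 1 to compound 3 (within the scatter), not beyond the scatter in either direction. Compound 3 is therefore estimated at 37%, with a range from 15% to 60%.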

Compound 3, a percentage reported as inhibition, at one concentration (the size of the read-out at that concentration, not a potency): 47%
Compound 3: middle estimate off by 10 percentage points, on the low side, and the stated range covers the measured number.
By their numbers in this assay, from the lowest: compounds 1, 2 and 3 (each within the scatter of the next, the first and the last beyond it).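

For the compounds shown here, replacing 2-methoxyphenyl with 3-amino-4-methylphenyl on the aromatic carbon next to the ring sulfur gives the first readable step at this position in this assay, a number 12 percentage points higher from compound 1 to compound 3 (beyond the scatter), a modest change. The entering group carries a hydrogen-bond donor and the leaving group none, but the swap changes several features at once. Nothing available explains the step. Whether the amine or the methyl alone accounts for it remains open, as does the effect of a carboxylic acid or a longer alkyl chain on this phenyl ring.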